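Butenyl for vinyl on the amide, second core

The source may report more compounds than this note shows. Statements on the series, on what has been measured and on what is new or still open speak of the compounds shown alone.

The series holds three measured compounds and one open one. Compound 1 `C=CC(=O)Nc1cc(Nc2nc(C)cc(-c3cn(C)c4ccccc34)n2)c(OC)cc1N(C)CCN(C)C` and compound 2 `CC/C=C\C(=O)Nc1cc(Nc2nc(C)cc(-c3cn(C)c4ccccc34)n2)c(OC)cc1N(C)CCN(C)C` share one core; compound 3 `C=CC(=O)Nc1cc(Nc2ncc(C#N)c(-c3cn(C)c4ccc(F)cc34)n2)c(OC)cc1N(C)CCN(C)C` and compound 4 `CC/C=C\C(=O)Nc1cc(Nc2ncc(C#N)c(-c3cn(C)c4ccc(F)cc34)n2)c(OC)cc1N(C)CCN(C)C` share another. The difference between the two cores is not broken down here.

In a functional assay on A549 cells (Homo sapiens) for antiproliferative activity, read by MTT assay, with a stated time of 72 h (a lower number here means a stronger inhibitor, a higher number a weaker inhibitor), compound 1 gives 2910 nM. Compound 2 gives 1090 nM in this assay. The change between them is but-1-en-1-yl in place of vinyl on a carbonyl carbon, and it made the step of a 2.7-fold lower number from compound 1 to compound 2 (0.43 log units; beyond the scatter). Compound 3 gives 9700 nM in this assay, the highest number of the three; compound 1 stands nearest to it and compound 2 furthest, both beyond the scatter.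

Compound 4 is compound 3 with but-1-en-1-yl in place of vinyl on a carbonyl carbon. The place reads the same, a carbonyl carbon whose other neighbour is an amide-type nitrogen, so this is the same change as from compound 1 to compound 2, carried onto the core of compound 3. It has one precedent only, and that precedent sits on a different core; whether the step carries over is not known, so the expectation is kept wide.

Within the data shown here, for compound 4 the expected step is a 2.6-fold lower number from compound 3 to compound 4 (0.41 log units; beyond the scatter), resting on the single precedent because a 2.7-fold lower number from compound 1 to compound 2 (0.43 log units; beyond the scatter) is the only measured instance of this change. Compound 4 is therefore estimated at 3800 nM in this assay. For compound 4 the expected range runs from 1800 nM to 8500 nM.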

Compound 4, half-maximal inhibitory concentration: 4730 nM
Beside the measured number, compound 4's estimate is 1.2-fold (0.10 log units) below it, within the range that was stated.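

In this assay, but-1-en-1-yl in place of vinyl on the carbonyl carbon gives a 2.1-fold lower number from compound 3 to compound 4 (0.31 log units; beyond the scatter), a step in the same direction as the one seen on the core of compound 1. The two steps agree in direction and do not differ in size beyond what repeated measurements would scatter: the same change on two cores in this assay, a 2.7-fold lower number (0.43 log units; beyond the scatter) from compound 1 to compound 2 and a 2.1-fold lower number (0.31 log units; beyond the scatter) from compound 3 to compound 4, 1.3-fold (0.11 log units) apart, within the scatter of two such steps This supports treating the change as transferable between these two cores in this assay, but it rests on two pairs only, says nothing about cores beyond these two, and does not show why the number falls; both steps are modest, and compound 4 remains a weak inhibitor in absolute terms at 4730 nM.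

The compounds shown leave open whether a longer chain than but-1-en-1-yl, or a chain ending in an amine such as dimethylamine, would extend the same step on either core. They also leave open how the step behaves on a core carrying the nitrile without the fluorine, or the fluorine without the nitrile, since the two cores here differ in more than one place.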